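The compounds below may be only part of what the source reports. "The series", "measured", "known", "first", "only" and "open" are said of these compounds alone.

Measured so far in an assay for inhibition of kynurenine 3-monooxygenase (Rattus norvegicus), tested at 10 uM; a higher number here means more inhibition at the concentration tested (going by the name of the read-out), a lower number less inhibition:
compound 1 `COC(=O)C(=O)/C=C(\O)c1ccccc1Cl` gives 31%
compound 2 `COC(=O)C(=O)/C=C(\O)c1cccc(Cl)c1Cl` gives 14%
compound 3 `COC(=O)C(=N)/C=C(\O)c1ccccc1Cl` gives 31%

Compound 2 differs from compound 1 by chloro in place of hydrogen on an aromatic carbon, and this change made a step of a number 17 percentage points lower from compound 1 to compound 2 (beyond the scatter). Compound 3 and compound 1 have different cores; the difference between the two cores is not broken down here, and their readings are level with each other within the usual scatter. Compound 4 `COC(=O)C(=N)/C=C(\O)c1cccc(Cl)c1Cl` has not yet been measured. It differs from compound 3 by chloro in place of hydrogen on an aromatic carbon, the same change that separates compound 2 from compound 1. The step from compound 3 to compound 4 is expected to be about the size of the earlier one, a number 17 percentage points lower from compound 3 to compound 4 (beyond the scatter), because a number 17 percentage points lower from compound 1 to compound 2 (beyond the scatter) was the outcome of this change on the core of compound 1. For compound 4 the estimated inhibition is 14%, with a likely range from 2% to 28%.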

Compound 4, a percentage reported as inhibition, at one concentration (the size of the read-out at that concentration, not a potency): 33%
Estimate against measurement, compound 4: 19 percentage points below; the measured number lies above the stated range.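

In this assay, putting chloro in place of hydrogen on the aromatic carbon does not give the same result on the two cores: the same change on two cores in this assay, a number 17 percentage points lower (beyond the scatter) from compound 1 to compound 2 and a number 2 percentage points higher (within the scatter) from compound 3 to compound 4, 19 percentage points apart, beyond the scatter of two such steps. On the core of compound 3 the change gives a number 2 percentage points higher from compound 3 to compound 4 (within the scatter), so the drop seen on the core of compound 1 does not carry over to this second pair. With a single pair on each core, this shows that the result on one core cannot be assumed for the other here, but not which part of the cores accounts for the gap or whether other changes behave the same way.

The compounds shown leave open how a methyl, a methoxy or an amine at this aromatic carbon would fare on each core. They also leave open what a carboxylic acid in place of the methyl ester would do.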